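The source may report more compounds than this note shows. Statements on the series, on what has been measured and on what is new or still open speak of the compounds shown alone.

Measured so far in an assay on isolated protein for displacement of a labelled ligand from 5-hydroxytryptamine receptor 6 (Homo sapiens); on this read-out lower numbers stand for stronger inhibition and higher numbers for weaker inhibition:
- compound 1 `O=C(NC[C@@H]1CCCc2cc(S(=O)(=O)c3cccc(F)c3)ccc21)[C@H]1CCCN1`: 0.631 nM
- compound 2 `O=C1CN(C[C@@H]2CCCc3cc(S(=O)(=O)c4cccc(F)c4)ccc32)CCN1`: 6.31 nM

Compound 2 gives the highest of the two numbers in this assay; the nearest is compound 1, and that gap is a 10-fold higher number from compound 1 to compound 2 (1.00 log units; beyond the scatter). Compound 3 `NCC(=O)NC[C@@H]1CCCc2cc(S(=O)(=O)c3cccc(F)c3)ccc21` has not been measured. It differs from compound 2 by ((aminomethyl)carbonyl)amino in place of 3-oxopiperazin-1-yl on a saturated chain carbon bound to a saturated ring carbon. For the measured compounds named here, the only step that bears on it is a 10-fold higher number from compound 1 to compound 2 (1.00 log units; beyond the scatter), which went from an acylated amine with a basic nitrogen to the ring; compound 3 returns to an acylated amine with a basic nitrogen, though without the ring of compound 1. A step back toward compound 1 is therefore expected, estimated as a 3.9-fold lower number from compound 2 to compound 3 (0.60 log units; beyond the scatter). For compound 3 the estimate in this assay is 1.6 nM, range 0.5 nM to 5 nM.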

Compound 3, inhibition constant: 0.316 nM
The estimate for compound 3 lay 5.1-fold (0.70 log units) above the measured number; measured number below the stated range.
By their numbers in this assay, from the lowest: compounds 3 and 1 (each within the scatter of the next); then compound 2.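

In this assay, the open-chain ((aminomethyl)carbonyl)amino group in place of 3-oxopiperazin-1-yl gives a 20-fold lower number from compound 2 to compound 3 (1.30 log units; beyond the scatter) and so recovers the level of compound 1 at this place. The ring of compound 1 is not required on the carbonyl carbon: aminomethyl in place of pyrrolidin-2-yl gives a 2.0-fold lower number from compound 1 to compound 3 (0.30 log units; within the scatter) and no change can be read from that step. No measurement on hand accounts for either step.

Open, as far as these compounds go, is whether the amine on that carbonyl carbon is required, as a plain acetyl group would show. Also open, from the compounds shown here alone, is how a dimethylamino group or a longer aminoalkyl chain would read.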